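Swapping the benzyl group on an inactive cinnamate ester

This account rests on a few compounds, and the source may have more. Where it says the series, first, only, none or still open, it means among the compounds named here.

Of the compounds shown here, two have been tested so far in a functional assay on PC-3 cells (Homo sapiens) for cytotoxicity, read by MTT assay, with a stated time of 72 h; a higher number here means a weaker inhibitor, a lower number a stronger inhibitor. Compound 1 `CCOc1ccc(COc2c(OC)cc(/C=C/C(=O)OCC(=O)Nc3ccccc3)cc2OC)cc1` gives only a limit of the assay, > 200000 nM. Compound 2 `COc1cc(/C=C/C(=O)OCC(=O)Nc2ccc(Cl)cc2)cc(OC)c1OCc1ccc(Cl)c(Cl)c1` likewise gives only a limit, > 200000 nM. So compound 2 stands at the limit itself, and the limit of > 200000 nM in this assay, at which 2 of the 2 values shown sit, summarises everything measured: no number has yet been reached in this assay.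

Compound 3 `CCOc1ccc(COc2c(OC)cc(/C=C/C(=O)OCC(=O)Nc3ccc(Cl)cc3)cc2OC)cc1` keeps the core of compound 2 and changes one group: 4-ethoxyphenyl in place of 3,4-dichlorophenyl on a saturated chain carbon bound to an oxygen on an aromatic ring. Among the compounds with values here, no step between two measured compounds is available to guide this change, and both measured compounds sit at the limit. The step expected from compound 2 to compound 3 in this assay is therefore none beyond the scatter: a number no higher from compound 2 to compound 3 (the limit leaves the size open). Compound 3 is expected to give about 200000 nM, with a likely range from 60000 nM to 400000 nM, most probably again reported only as a limit.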

Compound 3, half-maximal inhibitory concentration: > 200000 nM
Compound 3: only a limit was reported (the forecaster's own chance of this, stated with the estimate: 80%); the middle value sits exactly at the limit.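

Compound 3 also gives only a limit, so neither the step to it from compound 2 nor the step to it from compound 1 can be read: the limit of > 200000 nM in this assay, at which 3 of the 3 values shown sit. The compounds shown leave open which change, if any, would bring a measurable number in this assay.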